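Swapping a Thioether Arm for a Single Chloro

The compounds below may be only part of what the source reports. "The series", "measured", "known", "first", "only" and "open" are said of these compounds alone.

Three compounds share one core and differ only in the group on a saturated chain carbon bound to an aromatic carbon. In a functional assay on the whole organism with Rattus norvegicus as the target, with a stated time of 4 h, at a dose of 40 mg/kg by the intraperitoneal route (on this read-out lower numbers stand for less inhibition and higher numbers for more inhibition at the one dose given (going by the name of the read-out)), compound 1 `Cc1nc2c(OCc3ccccc3)cccn2c1CCC#N` gives 40%, compound 2 `CCOCc1c(C)nc2c(OCc3ccccc3)cccn12` gives 84%, and compound 3 `CSCc1c(C)nc2c(OCc3ccccc3)cccn12` gives 29%. Compound 3 stands lowest of the three, with compound 1 nearest and compound 2 furthest. The measured steps show how strongly this one spot steers the read-out: a number 44 percentage points higher from compound 1 to compound 2 (beyond the scatter), a number 11 percentage points lower from compound 1 to compound 3 (beyond the scatter) and a number 55 percentage points lower from compound 2 to compound 3 (beyond the scatter).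

Compound 4 `Cc1nc2c(OCc3ccccc3)cccn2c1Cl` takes a different route: chloro in place of (methylsulfanyl)methyl on an aromatic carbon. Within the data shown here, no measured pair exchanges a whole (methylsulfanyl)methyl arm for a single chloro, so the three steps bear on compound 4 only indirectly, by showing that changes here are large and run in either direction, the gap between compound 2 and compound 3 being the widest swing. Chloro, with one heavy atom against three, lies outside what has been tried, so its effect cannot be read off directly. A modest rise from compound 3 is expected, a number 16 percentage points higher from compound 3 to compound 4 (beyond the scatter), because compound 3 gives 29% and sits at the bottom of the range seen. Compound 4 is therefore estimated at 45%, with a wide range from 15% to 78%.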

Compound 4, a percentage reported as inhibition, in the whole organism at one dose (the size of the read-out at that dose, not a potency): 93%
For compound 4 the middle estimate is 48 percentage points below the measured one; the whole stated range lies below it.
By their numbers in this assay, from the lowest: compound 3; then compound 1; then compounds 2 and 4 (each within the scatter of the next).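

In this assay, putting chloro in place of the (methylsulfanyl)methyl arm on this aromatic carbon gives a number 64 percentage points higher from compound 3 to compound 4 (beyond the scatter), and putting it in place of the 2-cyanoethyl arm gives a number 53 percentage points higher from compound 1 to compound 4 (beyond the scatter), so the large swings at this spot are not limited to exchanges between chains. Against the ethoxymethyl arm the change reads a number 9 percentage points higher from compound 2 to compound 4 (within the scatter), which means that chloro and ethoxymethyl cannot be told apart in this test, even though chloro brings only a single heavy atom and no ring. The earlier compounds shown here all carried a chain here and could not show whether one was needed, whereas compound 4 shows that a high number at this one dose can be reached without any chain at this position.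

Nothing available explains why the single chloro gives such a different number from the (methylsulfanyl)methyl arm. The compounds shown leave open whether bromo or fluoro would behave like chloro at this spot, and whether an amine, a carboxylic acid or a longer ether chain such as propoxymethyl would keep the number high or bring it down.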